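The source may hold more compounds than are shown below. What is called first, only, known or untested is meant among the compounds shown, and "the series" means these compounds.

In an ADME assay on L1210/0 cells (Mus musculus) for cytotoxicity, with a stated time of 48 h (a higher number here means a weaker inhibitor, a lower number a stronger inhibitor), compound 1 `COc1ccccc1-c1ncnc2c1ncn2C[C@@H]1C[C@H](O)c2ccccc21` gives > 200000 nM as its reading, which is a limit of the assay and not a number. Compound 2 `CN(C)c1nc2c(=O)[nH]c(N)nc2n1COCCO` gives > 200000 nM as its reading, and this too is a limit. Compound 2 therefore has no number of its own, and the record so far amounts to the limit of > 200000 nM in this assay, at which 2 of the 2 values shown sit, and nothing finer. Among the measured compounds shown here, no measured step connects the two compounds.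

Compound 3 `Nc1nc2c(nc(O)n2COCCO)c(=O)[nH]1` keeps the shared core and the (2-hydroxyethoxy)methyl group of compound 2 and changes in one place, with hydroxy in place of dimethylamino on an aromatic carbon of the five-membered aromatic ring. For the measured compounds named here, with no measured step to go on, the expected shift in this assay is none beyond the scatter, with no preferred direction. The estimated step of a number no higher from compound 2 to compound 3 (the limit leaves the size open) is expected to stay that small. This expectation rests on compound 2 alone, whose > 200000 nM reading is a limit. For compound 3 the expected value is 200000 nM within an estimated range from 100000 nM to 400000 nM in this reading.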

Compound 3, half-maximal inhibitory concentration: > 200000 nM
Compound 3: a limit, no number (the forecaster's own chance of this, stated with the estimate: 85%); the middle value lies on the limit itself.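

Compound 3, like compound 2, gives only a limit in this assay, so no step can be read between compound 2 and compound 3 for hydroxy in place of dimethylamino. The compounds shown leave open how any of them would read as an actual number, since the record remains a single limit: the limit of > 200000 nM in this assay, at which 3 of the 3 values shown sit.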